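The source may report more compounds than this note shows. Statements on the series, on what has been measured and on what is new or still open speak of the compounds shown alone.

Measured in a functional assay on NTUB1 cells (Homo sapiens) for cytotoxicity, read by MTT assay, with a stated time of 72 h; on this read-out lower numbers stand for stronger inhibition and higher numbers for weaker inhibition:
- compound 1 `COc1ccc(OC)c(C(=O)/C=C/c2ccc(C(=O)O)cc2)c1`: 5700 nM
- compound 2 `CCCOC(=O)c1ccc(/C=C/C(=O)c2cc(OC)ccc2OC)cc1`: 6010 nM
- compound 3 `COc1ccc(OC)c(C(=O)/C=C/c2ccc(C(=O)OCc3ccccc3)cc2)c1`: 13300 nM

Of these three, compound 3 gives the highest number, at 13300 nM. Compound 4 `CCNC(=O)c1ccc(/C=C/C(=O)c2cc(OC)ccc2OC)cc1` differs from it as follows: ethylamino in place of benzyloxy on a carbonyl carbon. Among the compounds with values here, no measured step places a nitrogen at this carbonyl, so the amide itself is untested. The closest evidence is a 2.2-fold higher number from compound 2 to compound 3 (0.34 log units; beyond the scatter) and a 2.3-fold higher number from compound 1 to compound 3 (0.37 log units; beyond the scatter), both modest, while a 1.1-fold higher number from compound 1 to compound 2 (0.02 log units; within the scatter) stays within the scatter. Compound 4 lacks the benzyloxy group, so a modest move back towards compound 1 and compound 2 is expected in this assay. The expected change is a 1.7-fold lower number from compound 3 to compound 4 (0.22 log units; within the scatter). Compound 4 is estimated at 8000 nM, with an expected range of 3500 nM to 18000 nM.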

Compound 4, half-maximal inhibitory concentration: 3760 nM
Compound 4: the middle estimate sits 2.1-fold (0.33 log units) above what was measured; low and high end bracket the measured number.
By their numbers in this assay, from the lowest: compounds 4, 1 and 2 (each within the scatter of the next); then compound 3.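

In this assay the change from benzyloxy to ethylamino on the carbonyl carbon gives a 3.5-fold lower number from compound 3 to compound 4 (0.55 log units; beyond the scatter) and shows that this position also accepts an amide nitrogen. Ethylamino gives a 1.6-fold lower number from compound 2 to compound 4 (0.20 log units; within the scatter) and a 1.5-fold lower number from compound 1 to compound 4 (0.18 log units; within the scatter) and so shares one level with propoxy and hydroxy, from which only the benzyloxy of compound 3 stands apart. Nothing measured here explains this difference. As far as these compounds go, a benzylamino group on the same carbonyl carbon would separate the aromatic ring from the linking atom, and that comparison stays open, as does a longer chain on the amide nitrogen.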